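This account rests on a few compounds, and the source may have more. Where it says the series, first, only, none or still open, it means among the compounds named here.

Compound 2 `CCOC(=O)N1CCC(NC(=O)Nc2ccc(OC(F)(F)F)c(F)c2)CC1` stands highest in a physicochemical assay for lipophilicity, read by HPLC, with a stated time of 90 min, tested at 100 uM (a lower number here means a more polar compound, a higher number a more lipophilic compound), among the three measured compounds, giving 5.94. Within the data shown here, compound 1 `CCOC(=O)N1CCC(NC(=O)Nc2ccc(C(F)(F)F)c(F)c2)CC1` gives 5.46, and the change a number 0.48 log units higher from compound 1 to compound 2 (beyond the scatter) is the only single-point step available. Compound 3 `O=C(CC1CCN(C(=O)C2CC2)CC1)Nc1ccc(OC(F)(F)F)c(F)c1` differs from compound 2 in more than one place. In this assay compound 3 gives 5.11. Compound 4 `O=C(Nc1ccc(OC(F)(F)F)c(F)c1)NC1CCN(C(=O)C2CCOCC2)CC1` changes compound 2 at a different position: oxan-4-yl in place of ethoxy on a carbonyl carbon. Among the measured compounds shown here, no measured step touches this position, so the expectation rests on the group sizes alone; a step of a number 0.34 log units lower from compound 2 to compound 4 (beyond the scatter) is expected, within or just beyond the scatter. Compound 4 is therefore estimated at 5.6, with a plausible range from 5.1 to 6.1.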

Compound 4, partition coefficient: 3.73
Compound 4: middle estimate off by 1.87 log units, on the high side; the whole stated range lies above it.
By their numbers in this assay, from the lowest: compound 4; then compound 3; then compound 1; then compound 2.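

At this position, the carbonyl carbon on the amide-type nitrogen in a ring, swapping ethoxy for oxan-4-yl gives a number 2.21 log units lower from compound 2 to compound 4 (beyond the scatter) in this assay. The entering group is the larger of the two, yet the number falls, so group size alone does not set the reading here. Nothing measured among these compounds explains the fall. From the compounds shown here alone, it remains open whether the ring oxygen or the loss of ethoxycarbonyl matters more; cyclohexyl on the same carbonyl would help separate the two.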